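Turning One Ring Stereocentre in a Nitrate Ester Series

The source may report more compounds than this note shows. Statements on the series, on what has been measured and on what is new or still open speak of the compounds shown alone.

Measured so far in a functional assay on the whole organism for inhibition, with Rattus norvegicus as the target; on this read-out higher numbers stand for an effect only at larger amounts of compound and lower numbers for an effect already at smaller amounts:
compound 1, `O=[N+]([O-])O[C@H]1CO[C@H]2[C@@H]1OC[C@H]2N1CCN(CCCSc2ccccc2)CC1`, gives 12.5 mg/kg; > 25 mg/kg (2 entries).
compound 2, `O=[N+]([O-])O[C@@H]1CO[C@H]2[C@@H]1OC[C@@H]2N1CCN(CCCSc2ccccc2)CC1`, gives > 25 mg/kg.

For compound 1 the second of its entries is a limit of the assay rather than a number. For compound 2 the only entry is a limit of the assay, and a further entry gives no single number, so compound 2 stands only at a bound. Compound 3, `O=[N+]([O-])O[C@@H]1CO[C@H]2[C@@H]1OC[C@H]2N1CCN(CCCSc2ccccc2)CC1`, is yet to be measured in this assay. (the two compounds have the same atoms and bonds and differ only in configuration as drawn: 1 of 4 stereo elements differ; a stereocentre at a saturated ring carbon is drawn S in compound 2 and R in compound 3). For the measured compounds named here, no step between two measured compounds is available to gauge such a change, but the fact that compounds 1 and 2 differ only in configuration as drawn the fact that compounds 1 and 2 differ only in the configuration as drawn shows that a change of this kind can leave values close to the limit. The step of a number no higher from compound 2 to compound 3 (the limit leaves the size open) is therefore expected to be small, not beyond the usual scatter. Compound 3 is estimated at 25 mg/kg, between 10 mg/kg and 50 mg/kg.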

Compound 3, minimum effective dose: > 25 mg/kg
Compound 3 gave a limit, no number (the forecaster's own chance of this, stated with the estimate: 55%); the middle value sits exactly at the limit.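

For the compounds shown here, compound 2 and compound 3 both stand only at a limit in this assay, not at a number, so no step between them can be read. The compounds shown leave open whether turning this one ring stereocentre changes the dose needed for an effect at all.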